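Swapping Hydrogen for Chloro on the Shared Core

The source may hold more compounds than are shown below. What is called first, only, known or untested is meant among the compounds shown, and "the series" means these compounds.

Compound 1 `O=C(/C=C/OC1=CC=C1)Nc1nc2ccc([N+](=O)[O-])cc2s1`: 597 umol/kg
Compound 2 `O=C(/C=C/OC1=CC=C1)Nc1nc2ccccc2s1`: 781 umol/kg

Among the compounds with values here, in a functional assay on the whole organism (Hindlimb, strain albino) with Mus musculus as the target, in the maximal electroshock model, with a stated time of 0.5 h (a lower number here means that less compound is needed, a higher number that more compound is needed for the effect), compound 2 cannot be told apart from compound 1, as the only measured step, a 1.3-fold higher number from compound 1 to compound 2 (0.12 log units; within the scatter), stays within the scatter. Compound 3 `O=C(/C=C/OC1=CC=C1)Nc1nc2ccc(Cl)cc2s1` has chloro in place of hydrogen on an aromatic carbon of compound 2 (chloro in place of hydrogen on an aromatic carbon). That single step replaced nitro with hydrogen on an aromatic carbon, so no change beyond the scatter is expected here. The expected size of the change is a 1.2-fold lower number from compound 2 to compound 3 (0.08 log units; within the scatter). For compound 3 the estimated value is 650 umol/kg, with an expected range of 330 umol/kg to 1250 umol/kg.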

Compound 3, dose for half-maximal effect: 544 umol/kg
Beside the measured number, compound 3's estimate is 1.2-fold (0.08 log units) above it; low and high end bracket the measured number.
By their numbers in this assay, from the lowest: compounds 3, 1 and 2 (each within the scatter of the next).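

Compound 3 gives this aromatic carbon a third substituent, and in this assay the step from hydrogen to chloro (a 1.4-fold lower number from compound 2 to compound 3 (0.16 log units; within the scatter)) stays within the scatter. The swap of nitro for chloro (a 1.1-fold lower number from compound 1 to compound 3 (0.04 log units; within the scatter)) also stays within the scatter, so hydrogen, nitro and chloro on this carbon cannot be told apart in this model. Nothing measured here offers a reason for this. From the compounds shown here alone, whether an amine, a methoxy group or a carboxylic acid on this carbon would shift the number beyond the scatter remains open. So does the effect of changes elsewhere on the shared core.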